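3,5-Dimethoxyphenyl in place of 3,5-dichlorophenyl: working notes

A few compounds are considered here, and "the series" means these few. Any claim that something is new, unique, unknown or untested is made for them only; others in the source may bear on it.

In a functional assay on HCT-116 cells (Homo sapiens) for inhibition, read by MTT assay, with a stated time of 72 h (on this read-out higher numbers stand for weaker inhibition and lower numbers for stronger inhibition), compound 1 (`Cc1nc(-c2ccccc2F)c(C(=O)N2CCN(c3cc(Cl)cc(Cl)c3)CC2)o1`) gives 319 nM and compound 2 (`Cc1nc(-c2ccc(F)cc2)c(C(=O)N2CCN(c3cc(Cl)cc(Cl)c3)CC2)o1`) gives 484 nM. Among the compounds with values here, these two values lie within the scatter of each other, so compound 1 is not separated from its only neighbour. Compound 3 (`COc1cc(OC)cc(N2CCN(C(=O)c3oc(C)nc3-c3ccccc3F)CC2)c1`) carries 3,5-dimethoxyphenyl in place of 3,5-dichlorophenyl on an amine nitrogen in a ring. Within the data shown here, the one measured step, a 1.5-fold higher number from compound 1 to compound 2 (0.18 log units; within the scatter), lies on the fluorophenyl group, so no measured step covers this place. From the compounds shown here alone, its size remains open. A modest estimated change is expected, a 1.9-fold higher number from compound 1 to compound 3 (0.27 log units; within the scatter). For compound 3, the expected value is 600 nM, with an estimated range of 180 nM to 2000 nM.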

Compound 3, half-maximal inhibitory concentration: 26 nM
Compound 3: the middle estimate sits 23-fold (1.36 log units) above what was measured; measured number below the stated range.
By their numbers in this assay, from the lowest: compound 3; then compounds 1 and 2 (each within the scatter of the next).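

With 3,5-dimethoxyphenyl in place of 3,5-dichlorophenyl on the amine nitrogen in the ring, the series shows a 12-fold lower number from compound 1 to compound 3 (1.09 log units; beyond the scatter) and so its first step beyond the scatter. The other step, a 1.5-fold higher number from compound 1 to compound 2 (0.18 log units; within the scatter) on the fluorophenyl group, stays within the scatter, so the aryl group on this nitrogen is the only place shown where a change separates compounds. No evidence bears on the cause of this large step.

Still open, from the compounds shown here alone, is whether 3,5-dimethoxyphenyl gives a step of similar size on compound 2. Also open, going by these compounds, is whether ethoxy or amino groups in place of the methoxy groups keep the lower number.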